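Chlorophenyl hydrazones at the limit: the step to compound 4

The source may report more compounds than this note shows. Statements on the series, on what has been measured and on what is new or still open speak of the compounds shown alone.

Measured in a functional assay on MCF7 cells (Homo sapiens) for antiproliferative activity, read by MTT assay, with a stated time of 72 h; a higher number here means a weaker inhibitor, a lower number a stronger inhibitor:
- compound 1 `CCCSc1nc(N/N=C/c2ccc(Cl)cc2)c2nnn(Cc3ccccc3)c2n1`: > 64000 nM (a limit)
- compound 2 `CCCSc1nc(N/N=C/c2cccc(Cl)c2)c2nnn(Cc3ccccc3)c2n1`: > 64000 nM (a limit)
- compound 3 `CCCSc1nc(N/N=C/c2c[nH]c3ccccc23)c2nnn(Cc3ccccc3)c2n1`: 9010 nM

Compound 2 gives > 64000 nM in this assay, which is a limit of the assay and not a number. The readings so far are dominated by the limit of > 64000 nM in this assay, at which 2 of the 3 values shown sit.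

The next compound is compound 4 `CCCSc1nc(N/N=C(\C)c2ccc(Br)cc2)c2nnn(Cc3ccccc3)c2n1`, and the change is a group of 10 heavy atoms (8 carbon, 1 nitrogen, 1 bromine; one six-membered aromatic ring of carbon only) in place of a group of 9 heavy atoms (7 carbon, 1 nitrogen, 1 chlorine; one six-membered aromatic ring of carbon only), on a nitrogen on an aromatic ring.

Within the data shown here, three measured steps bear on this. Among the measured compounds shown here, the first is a step that the two limits leave unreadable from compound 1 to compound 2. The other two, an at least 7.1-fold lower number from compound 2 to compound 3 (0.85 log units; beyond the scatter) and an at least 7.1-fold lower number from compound 1 to compound 3 (0.85 log units; beyond the scatter), both bring in the 1H-indol-3-yl group, which compound 4 does not carry. For the measured compounds named here, compound 4 keeps a six-membered aromatic ring of carbon only with a halogen on it, as compound 1 and compound 2 do, and compound 3 is the only one with a readable value. The expected outcome is a number no higher from compound 2 to compound 4 (the limit leaves the size open), meaning no step beyond the scatter, and a reported limit is quite likely.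

The estimate for compound 4 is 64000 nM, with an expected range of 20000 nM to 128000 nM.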

Compound 4, half-maximal inhibitory concentration: 13000 nM
For compound 4 the middle estimate is 4.9-fold (0.69 log units) above the measured one; the whole stated range lies above it.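

In this assay a halogen on a six-membered aromatic ring of carbon only no longer goes with a reading at the limit. Compound 4 gives 13000 nM, so a readable value here does not depend on the 1H-indol-3-yl group. The change on the nitrogen gives an at least 4.9-fold lower number from compound 2 to compound 4 (0.69 log units; beyond the scatter) and an at least 4.9-fold lower number from compound 1 to compound 4 (0.69 log units; beyond the scatter), both beyond the scatter. Going by these compounds, the full size of both steps stays open because their starting values are limits and not numbers: the limit of > 64000 nM in this assay, at which 2 of the 4 values shown sit.

The entering group differs from the leaving groups both in bromine for chlorine and in one more carbon, and the compounds shown do not separate the two. On these data alone, how an amine or a carboxylic acid on this ring would read also remains open.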